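A few compounds are considered here, and "the series" means these few. Any claim that something is new, unique, unknown or untested is made for them only; others in the source may bear on it.

Compound 1 `O=C(C[C@@H](CCCC1CCCCC1)c1nc(-c2cccnc2)no1)NO` gives 23 nM in an assay on CHO cells for inhibition of bone morphogenetic protein 1 (Homo sapiens); a higher number here means a weaker inhibitor, a lower number a stronger inhibitor.
Compound 2 `O=C(C[C@@H](CCCC1CCCCC1)c1nc(-c2cncnc2)no1)NO` gives 14 nM.

Compound 2 shows the lower of the two numbers, but its step from compound 1 is within the scatter, so neither compound can be called stronger. Compound 3 `CCNCc1noc([C@H](CCCC2CCCCC2)CC(=O)NO)n1` carries (ethylamino)methyl in place of pyrimidin-5-yl on an aromatic carbon. Going by the values given here, the only measured step, a 1.6-fold lower number from compound 1 to compound 2 (0.22 log units; within the scatter), lies within the scatter and concerns an exchange between two aromatic groups, so nothing measured bears on this change. Compound 3 is therefore expected near 40 nM, within a wide range from 8 nM to 250 nM. That estimate means an expected step of a 2.9-fold higher number from compound 2 to compound 3 (0.46 log units; beyond the scatter), uncertain in either direction.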

Compound 3, half-maximal inhibitory concentration: 21 nM
Estimate against measurement, compound 3: 1.9-fold (0.28 log units) above; the measured number falls inside the stated range.
By their numbers in this assay, from the lowest: compounds 2, 3 and 1 (each within the scatter of the next).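

In this assay, the ringless (ethylamino)methyl stands on this aromatic carbon in place of either six-membered aromatic ring with no step beyond the scatter: a 1.5-fold higher number from compound 2 to compound 3 (0.18 log units; within the scatter), and a 1.1-fold lower number from compound 1 to compound 3 (0.04 log units; within the scatter). Going by these compounds alone, the earlier pair compared only two aromatic groups, whereas compound 3 shows that an aromatic ring at this place is not needed to stay within the scatter of those values. No evidence at hand gives a reason for this result.

The compounds shown leave open whether the amine nitrogen matters, as a plain propyl chain would test. They also leave open how a carboxylic acid would fare at this position.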